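This account rests on a few compounds, and the source may have more. Where it says the series, first, only, none or still open, it means among the compounds named here.

Compounds measured so far in an assay on isolated protein for inhibition of kallikrein-7 (Homo sapiens), read by fluorescence, with stated times of 10 min and 30 min; a higher number here means a weaker inhibitor, a lower number a stronger inhibitor:

Compound 1, `CC1=NC(c2cn(S(=O)(=O)c3ccccc3)c3ccc(C)cc23)CN1`, gives 17000 nM.
Compound 2, `CC1=NC(c2cn(S(=O)(=O)c3ccccc3Cl)c3ccc(C)cc23)CN1`, gives 1200 nM.
Compound 3, `CC1=NC(c2cn(S(=O)(=O)c3ccccc3F)c3ccc(C)cc23)CN1`, gives 4100 nM.

Compound 3 stands second highest of the three numbers: compound 2 sits nearest, with a 3.4-fold higher number from compound 2 to compound 3 (0.53 log units; beyond the scatter), and compound 1 sits furthest, with a 4.1-fold lower number from compound 1 to compound 3 (0.62 log units; beyond the scatter). The next compound, compound 4, `CC1=NC(c2cn(S(=O)(=O)c3ccccc3C#N)c3ccc(C)cc23)CN1`, differs from compound 3 in one place: cyano in place of fluoro on an aromatic carbon. Among the compounds with values here, two measured steps bear on this change. Both replacements of the hydrogen in compound 1 at this position lowered the number: a 14-fold lower number from compound 1 to compound 2 (1.15 log units; beyond the scatter) and a 4.1-fold lower number from compound 1 to compound 3 (0.62 log units; beyond the scatter). Chloro did better than fluoro, as shown by a 3.4-fold higher number from compound 2 to compound 3 (0.53 log units; beyond the scatter). A cyano group is larger than fluoro, so a further fall in this assay is expected, of modest size. Compound 4 is estimated at 1500 nM, with a likely range from 500 nM to 6000 nM, which means an expected step of a 2.7-fold lower number from compound 3 to compound 4 (0.44 log units; beyond the scatter).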

Compound 4, half-maximal inhibitory concentration: 6700 nM
Estimate against measurement, compound 4: 4.5-fold (0.65 log units) below, and the stated range ends below it.
By their numbers in this assay, from the lowest: compound 2; then compounds 3 and 4 (each within the scatter of the next); then compound 1.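

At this place on the ring, more heavy atoms alone do not bring a lower number: in this assay cyano in place of fluoro gives only a step within the scatter (a 1.6-fold higher number from compound 3 to compound 4 (0.21 log units; within the scatter)), so the two groups cannot be told apart. Cyano still beats hydrogen (a 2.5-fold lower number from compound 1 to compound 4 (0.40 log units; beyond the scatter)) but falls short of chloro (a 5.6-fold higher number from compound 2 to compound 4 (0.75 log units; beyond the scatter)). Nothing measured here explains why chloro stands apart from the other groups.

On these data alone, it remains open whether bromo, methyl or methoxy at this same place would match chloro. An amine or a carboxylic acid here is equally untested in what is shown.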